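The source may hold more compounds than are shown below. What is called first, only, known or untested is meant among the compounds shown, and "the series" means these compounds.

In a functional assay on CLL cells (Homo sapiens) for cytotoxicity, read by MTT assay, with a stated time of 48 h (on this read-out lower numbers stand for an effect already at smaller amounts and higher numbers for an effect only at larger amounts of compound), compound 1 (`C=C(CC)C(=O)c1ccc(OCC(=O)Nc2cccc(C(=O)O)c2)c(Cl)c1Cl`) gives 20600 nM, compound 2 (`C=C(CC)C(=O)c1ccc(OCC(=O)NC(CS)C(=O)OCC)c(Cl)c1Cl`) gives 4800 nM and compound 3 (`C=C(CC)C(=O)c1ccc(OCC(=O)Nc2ccc(C(=O)O)cc2)c(Cl)c1Cl`) gives 5000 nM. Compound 3 therefore sits level with compound 2, a 1.0-fold higher number from compound 2 to compound 3 (0.02 log units; within the scatter), and apart from compound 1, a 4.1-fold lower number from compound 1 to compound 3 (0.61 log units; beyond the scatter). Compound 4 (`C=C(CC)C(=O)c1ccc(OCC(=O)Nc2ccc(C(=O)OC)cc2)c(Cl)c1Cl`) brings (methyl in place of hydrogen on an oxygen next to a carbonyl group), which turns carboxy into methoxycarbonyl. Within the data shown here, no measured step makes this exact change. The closest guide is compound 2, which carries ethoxycarbonyl and no carboxy, and its value gives a 4.3-fold lower number from compound 1 to compound 2 (0.63 log units; beyond the scatter) but no separation in a 1.0-fold higher number from compound 2 to compound 3 (0.02 log units; within the scatter). Only a small shift towards a lower number in this assay is expected, not clearly beyond the scatter, with the estimated step of a 1.7-fold lower number from compound 3 to compound 4 (0.22 log units; within the scatter). The estimate for compound 4 is 3000 nM, with an expected range of 1000 nM to 9000 nM.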

Compound 4, half-maximal effective concentration: 4100 nM
Compound 4: middle estimate off by 1.4-fold (0.14 log units), on the low side, within the range that was stated.
By their numbers in this assay, from the lowest: compounds 4, 2 and 3 (each within the scatter of the next); then compound 1.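

On the 4-carboxyphenyl amide, methyl in place of hydrogen on the oxygen next to the carbonyl group gives a 1.2-fold lower number from compound 3 to compound 4 (0.09 log units; within the scatter) in this assay. Among these compounds, this is the first direct reading of the carboxy to methoxycarbonyl change, and on this read-out it does not separate the ester from the free acid. No measurement here bears on what lies behind this result. Still open, going by these compounds, is whether the same holds for the 3-carboxyphenyl group of compound 1, and how a butyl ester or a primary carboxamide would read in place of the carboxy.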